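This account rests on a few compounds, and the source may have more. Where it says the series, first, only, none or still open, it means among the compounds named here.

The account concerns three compounds that share one core and differ in a single saturated chain. Compound 1 `CCCCCCCCCCNC(=O)CCCSC[C@H](NC(=O)OCc1ccccc1)C(=O)Nc1ccccc1` was examined in an assay for inhibition of NAD-dependent protein deacylase sirtuin-6 (Homo sapiens), read by HPLC, with stated times of 15 min and 1 h, tested at 333 uM (a lower number here means less inhibition, a higher number more inhibition at the concentration tested (going by the name of the read-out)), where compound 1 gives 28%. Among the measured entries, compound 1 holds the only number reported; compound 2 `CCCCCCCCNC(=O)CCCSC[C@H](NC(=O)OCc1ccccc1)C(=O)Nc1ccccc1` in this assay is recorded as "not active" (no number reported), with no figure attached. Compound 3 `CCCCNC(=O)CCCSC[C@H](NC(=O)OCc1ccccc1)C(=O)Nc1ccccc1` has not yet been tested in this assay. Its structure departs from that of compound 1 by one change: hydrogen in place of hexyl on a saturated chain carbon, four bonds along the chain from an amide-type nitrogen. Within the data shown here, no step between two measured compounds is available to gauge this change directly. What can be said is that compound 2 in this assay is recorded as "not active" (no number reported), while compound 1 gives 28%. On that basis a downward step beyond the usual scatter is expected, a number 23 percentage points lower from compound 1 to compound 3 (beyond the scatter), and it may well end in an entry without a number at all. Compound 3 is therefore estimated at 5% in this assay, with a range from 0% to 18%.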

Compound 3, a percentage reported as inhibition, at one concentration (the size of the read-out at that concentration, not a potency): 26%
For compound 3 the middle estimate is 21 percentage points below the measured one; measured number outside the range, above it.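

The step of a number 2 percentage points lower from compound 1 to compound 3 (within the scatter) shows that, in this assay, hydrogen can stand in place of hexyl on a saturated chain carbon, four bonds along the chain from an amide-type nitrogen, without a shift beyond the usual scatter, so a number in this assay does not depend on those hexyl carbons. Compound 2, taken alone beside compound 1, pointed to a loss as the chain is cut, but compound 3 goes against that reading: a number appears on either side of the chain of compound 2, and any step to or from compound 2 cannot be read, as it has no figure. No measurement shown here offers an explanation for this result.

From the compounds shown here alone, whether the entry for compound 2 marks a real gap or a reading close to the others stays open, and these single-concentration readings say nothing about potency. Also open, going by these compounds, is what a longer chain, a terminal amine or a carboxylic acid at this place would do to the read-out, as is the outcome of removing the remaining chain altogether.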